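Sulfonyl substituent swap on the furo-amide core and solubility

This account rests on a few compounds, and the source may have more. Where it says the series, first, only, none or still open, it means among the compounds named here.

Measured compounds:
compound 1, `O=C(NCc1ccc(S(=O)(=O)c2cc(F)cc(F)c2)cc1)c1cc2cnccc2[nH]1`: 1600 nM
compound 2, `O=C(NCc1ccc(S(=O)(=O)N2CCOCC2)cc1)c1cc2ccncc2o1`: 101000 nM
compound 3, `O=C(NCc1ccc(S(=O)(=O)N2CCOCC2)cc1)c1cc2cnccc2[nH]1`: 42000 nM

In a physicochemical assay for solubility, measured as kinetic solubility, with a stated time of 24 h, at pH 7.4 (on this read-out higher numbers stand for higher solubility and lower numbers for lower solubility), compound 2 gives the highest of the three numbers; its nearest neighbour is compound 3, and its furthest is compound 1. Compound 4, `Cc1ccc(S(=O)(=O)c2ccc(CNC(=O)c3cc4ccncc4o3)cc2)cn1`, has not been measured in this assay. It differs from compound 2 in one place: 6-methylpyridin-3-yl in place of morpholin-4-yl on a sulfonyl sulfur.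

Among the compounds with values here, one measured step bears on this change directly. Between compound 1 and compound 3 the same sulfonyl sulfur carries an aryl group in one and morpholin-4-yl in the other, and the result was a 26-fold higher number from compound 1 to compound 3 (1.42 log units; beyond the scatter). Compound 4 runs that exchange in the opposite direction, aryl entering in place of morpholin-4-yl, so a drop in this assay is expected. The entering 6-methylpyridin-3-yl group differs from the 3,5-difluorophenyl of compound 1, and the core of compound 2 differs from that of compound 1, so the size is uncertain; the step of a 2.4-fold lower number from compound 2 to compound 3 (0.38 log units; beyond the scatter) shows the core choice itself matters modestly.

The step from compound 2 to compound 4 is therefore expected to be a 10-fold lower number from compound 2 to compound 4 (1.00 log units; beyond the scatter). Compound 4 is estimated at 10000 nM, with a range from 2500 nM to 40000 nM.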

Compound 4, solubility: 47000 nM
Estimate against measurement, compound 4: 4.7-fold (0.67 log units) below; measured number outside the range, above it.
By their numbers in this assay, from the lowest: compound 1; then compounds 3 and 4 (each within the scatter of the next); then compound 2.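

On the core of compound 2, an aromatic group on the sulfonyl sulfur is compatible with a high number in this assay: the exchange of morpholin-4-yl for 6-methylpyridin-3-yl gives a 2.1-fold lower number from compound 2 to compound 4 (0.33 log units; beyond the scatter) and stays a modest step. Within the data shown here, the only earlier exchange at this position, a 26-fold higher number from compound 1 to compound 3 (1.42 log units; beyond the scatter) on another core and with 3,5-difluorophenyl as the aromatic group, is a large step, so morpholin-4-yl against an aromatic group does not by itself fix the size of the change across these two pairs. No measurement in hand accounts for the gap between these two steps or for the modest size of the new one.

On these data alone, the two steps differ in both the aromatic group and the core, so it remains open whether the smaller step belongs to the 6-methylpyridin-3-yl group or to the core of compound 2, and 3,5-difluorophenyl on that core would separate the two. Also open, as far as these compounds go, is where a piperidin-1-yl group, an unsubstituted phenyl group or a dimethylamino group on the same sulfonyl sulfur would fall relative to compound 2 and compound 4.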